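Amide cap swap on the piperidine nitrogen of compound 1

This account rests on a few compounds, and the source may have more. Where it says the series, first, only, none or still open, it means among the compounds named here.

Within the data shown here, compound 1 `COCC(=O)N1CCC(NS(=O)(=O)c2ccc(NC(=O)c3ccccc3C)c3ccccc23)CC1` is the only compound with a single number: in an assay on L1.2 cells for binding affinity to C-C chemokine receptor type 8 (Homo sapiens) (on this read-out higher numbers stand for weaker inhibition and lower numbers for stronger inhibition), compound 1 gives 15.8 nM. Compound 2 `Cc1ccccc1C(=O)Nc1ccc(S(=O)(=O)NC2CCN(C(=O)[C@@H]3CCCN3)CC2)c2ccccc12` has several entries, giving 0.7 nM; 1 nM (2 entries) in this assay. Among the measured compounds shown here, no step between measured compounds is available. Compound 3 `CNC(=O)N1CCC(NS(=O)(=O)c2ccc(NC(=O)c3ccccc3C)c3ccccc23)CC1` differs from compound 1 by methylamino in place of methoxymethyl on a carbonyl carbon. For the measured compounds named here, with no measured precedent for this change, the step is expected to be small, in either direction and likely not beyond the scatter, so for compound 3 the expected value is 12 nM with a range of 4 nM to 40 nM, meaning an expected step of a 1.3-fold lower number from compound 1 to compound 3 (0.12 log units; within the scatter).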

Compound 3, inhibition constant: 0.7 nM
Estimate against measurement, compound 3: 17-fold (1.23 log units) above, and the stated range ends above it.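

The cap on the piperidine nitrogen is a sensitive position: methylamino in place of methoxymethyl on a carbonyl carbon gives a 23-fold lower number from compound 1 to compound 3 (1.35 log units; beyond the scatter) in this assay. A swap this small in heavy atoms, from one short acyclic group to another, is enough for a large step. Repeat entries at the low end of this read-out agree closely, so assay noise is an unlikely account of the step: the several entries of compound 2 in this assay, 0.7 nM; 1 nM (2 entries)

Open, from the compounds shown here alone, is how the value responds to ethylamino, dimethylamino or a plain methyl on the same carbonyl carbon. Without these, the step cannot be assigned to the hydrogen-bond donor entering or the hydrogen-bond acceptor leaving.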